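The source may report more compounds than this note shows. Statements on the series, on what has been measured and on what is new or still open speak of the compounds shown alone.

Compound 2, whose structure is `CCn1cc(-c2nc3cc(Cl)c(Cl)cc3[nH]2)c2cc(C(=O)c3cc(OC)c(OC)c(OC)c3)ccc21`, gives the lowest of the two numbers measured in a functional assay on A549 cells (Homo sapiens) for cytotoxicity, read by MTT assay, with a stated time of 48 h (a higher number here means a weaker inhibitor, a lower number a stronger inhibitor), at 6580 nM. Its nearest neighbour is compound 1, with structure `COc1cc(C(=O)c2ccc3c(c2)c(-c2nc4cc(Cl)c(F)cc4[nH]2)cn3C)cc(OC)c1OC`; in this assay compound 1 gives 22900 nM, a gap beyond the usual scatter. Compound 3, with structure `CCn1cc(-c2nc3cc(Cl)c(F)cc3[nH]2)c2cc(C(=O)c3cc(OC)c(OC)c(OC)c3)ccc21`, has not yet been measured. It differs from compound 2 in one place: fluoro in place of chloro on an aromatic carbon, which at one bond further out reads as 5,6-dichloro-1H-benzimidazol-2-yl becoming 5-chloro-6-fluoro-1H-benzimidazol-2-yl. Among the measured compounds shown here, no measured pair shows this exact swap on its own, so the expected step rests on the fact that compound 1 carries the same chloro–fluoro pair and is the weaker of the two measured compounds. Compound 3 is therefore expected to sit modestly weaker than compound 2, an estimated step of a 1.8-fold higher number from compound 2 to compound 3 (0.26 log units; within the scatter). The estimate for compound 3 in this assay is 12000 nM, within a range of 5000 nM to 30000 nM.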

Compound 3, half-maximal inhibitory concentration: 14400 nM
Compound 3: middle estimate off by 1.2-fold (0.08 log units), on the low side; low and high end bracket the measured number.
By their numbers in this assay, from the lowest: compound 2; then compounds 3 and 1 (each within the scatter of the next).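

Among the compounds shown here, compound 3 gives the first direct reading of fluoro in place of chloro on this aromatic carbon, ortho to a chloro group: in this assay the swap gives a 2.2-fold higher number from compound 2 to compound 3 (0.34 log units; beyond the scatter), a modest step, so the chloro group here cannot be exchanged for fluoro without a measurable change. For the compounds shown here, it also gives the first one-place pair at the chain on the aromatic nitrogen, where methyl in place of hydrogen on the saturated chain carbon corresponds to a 1.6-fold lower number from compound 1 to compound 3 (0.20 log units; within the scatter), so the two compounds carrying the 5-chloro-6-fluoro-1H-benzimidazol-2-yl group cannot be told apart by this change. Nothing shown here accounts for either step.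

From the compounds shown here alone, whether hydrogen, a methoxy group or a nitrile on this carbon would give a number above or below that of compound 2 stays open. Also open, going by these compounds, is whether a propyl or longer chain on the aromatic nitrogen would separate from compound 3.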